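The source may report more compounds than this note shows. Statements on the series, on what has been measured and on what is new or still open speak of the compounds shown alone.

Working notes on the series.

Among the compounds with values here, compound 3 `O=C(NS(=O)(=O)c1ccccc1)n1ccc2c(Cl)ccnc21` gives 47.6% in a functional assay on HT-29 cells (Homo sapiens) for antiproliferative activity, read by MTT assay, with a stated time of 24 h, tested at 10 uM (a higher number here means more inhibition at the concentration tested (going by the name of the read-out), a lower number less inhibition), and holds the highest of the three numbers measured so far. Its nearest neighbour is compound 2 `Cc1ccc(S(=O)(=O)NC(=O)n2ccc3cccnc32)cc1`, which gives 33.4% in this assay; furthest is compound 1 `O=C(NS(=O)(=O)c1ccccc1)n1ccc2cccnc21`, which gives 23.6%. Two single-point steps are available. Methyl in place of hydrogen on an aromatic carbon gives a number 9.8 percentage points higher from compound 1 to compound 2 (within the scatter). Within the data shown here, the other step, the one that brings chloro in, gives a number 24 percentage points higher from compound 1 to compound 3 (beyond the scatter), the one change in the set that moves the read-out beyond the scatter.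

The next compound is compound 4 `CN(C)c1ccnc2c1ccn2C(=O)NS(=O)(=O)c1ccccc1`. Relative to compound 3 the difference is dimethylamino in place of chloro on an aromatic carbon. Among the measured compounds shown here, no measured step introduces dimethylamino anywhere, so the only step that bears on this change is the one that brought chloro in, a number 24 percentage points higher from compound 1 to compound 3 (beyond the scatter); taking chloro out is expected to give back some or all of that gain, while the entering dimethylamino is an unknown. The expected step is therefore a number 17.6 percentage points lower from compound 3 to compound 4 (beyond the scatter), downward, of roughly the size of the chloro step but with a wide band. Compound 4 is estimated at 30%, within 15% to 50%.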

Compound 4, a percentage reported as inhibition, at one concentration (the size of the read-out at that concentration, not a potency): 17.6%
Estimate against measurement, compound 4: 12.4 percentage points above; the measured number falls inside the stated range.
By their numbers in this assay, from the lowest: compounds 4, 1 and 2 (each within the scatter of the next, the first and the last beyond it); then compound 3.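

At the aromatic carbon opposite the ring nitrogen, the outcome depends on the group: dimethylamino in place of chloro gives a number 30 percentage points lower from compound 3 to compound 4 (beyond the scatter) in this assay, so the higher number of compound 3 does not carry over to this other substituent at the same place. Dimethylamino in place of hydrogen gives a number 6 percentage points lower from compound 1 to compound 4 (within the scatter), which leaves compound 4 level with the unsubstituted core of compound 1; of the two groups seen at this position, only chloro separates from hydrogen beyond the scatter. Nothing available accounts for the different outcomes of chloro and dimethylamino at this position.

The compounds shown leave open whether the chloro result extends to other halogens such as fluoro or bromo, and whether a primary amine, a methoxy group or a longer dialkylamino chain at this position would stay level with hydrogen, as dimethylamino does, or separate from it, as chloro does. They also leave open whether chloro at this position and the methyl group of compound 2 would add up in a single compound.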